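Working notes: a methylsulfanyl exchange across two cores

This account rests on a few compounds, and the source may have more. Where it says the series, first, only, none or still open, it means among the compounds named here.

Measured so far:
Compound 1 `CS/C(=N\C(=O)c1csc([N+](=O)[O-])c1)NC(=O)c1csc([N+](=O)[O-])c1`. In a functional assay on HepG2 cells (Homo sapiens) for cytotoxicity, read by MTT assay, with a stated time of 72 h (a lower number here means a stronger inhibitor of growth, a higher number a weaker inhibitor of growth), compound 1 gives > 100000 nM, which is a limit of the assay and not a number.
Compound 2 `CS/C(=N\C(=O)c1cc2ccccc2s1)NC(=O)c1cc2ccccc2s1`. In this assay compound 2 gives 53000 nM.
Compound 3 `O=C(/N=C(/NC(=O)c1csc([N+](=O)[O-])c1)[Se]Cc1ccccc1)c1csc([N+](=O)[O-])c1`. In this assay compound 3 gives 62800 nM.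

Compound 3 differs from compound 1 by one change: a group of 8 heavy atoms (7 carbon, 1 selenium; one six-membered aromatic ring of carbon only) in place of a group of 2 heavy atoms (1 carbon, 1 sulfur; no ring), on a carbon with a double bond to nitrogen. That change gave an at least 1.5-fold lower number from compound 1 to compound 3 (0.20 log units; that floor lies within the scatter). The size of this step is bounded only from one side because of the limit of > 100000 nM in this assay, at which 1 of the 3 values shown sits, so how much further it may reach is not known.

The two cores, that of compound 1 and that of compound 2, differ in a way that is not broken down here. Compound 2 and compound 3 sit within the scatter of each other, so no order between them is claimed.

Compound 4 `O=C(/N=C(/NC(=O)c1cc2ccccc2s1)[Se]Cc1ccccc1)c1cc2ccccc2s1` has not yet been measured. It stands to compound 2 as compound 3 stands to compound 1: a group of 8 heavy atoms (7 carbon, 1 selenium; one six-membered aromatic ring of carbon only) in place of a group of 2 heavy atoms (1 carbon, 1 sulfur; no ring), on a carbon with a double bond to nitrogen. The place lines of the two changes read the same, so this is the same change made on the second core.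

Within the data shown here, the expectation for compound 4 rests on the single measured step, which gave an at least 1.5-fold lower number from compound 1 to compound 3 (0.20 log units; that floor lies within the scatter) from a starting point that was itself only a limit. Compound 2 starts from a number, so a step of similar direction is expected, and the estimated step from compound 2 to compound 4 is a 1.3-fold lower number from compound 2 to compound 4 (0.12 log units; within the scatter). Compound 4 is estimated to give 40000 nM in this assay, with a range from 15000 nM to 100000 nM expected to hold most repeats. Nothing among the shown compounds tells whether the second core will carry the change the same way, so the range is kept wide.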

Compound 4, concentration for total growth inhibition: 49000 nM
Estimate against measurement, compound 4: 1.2-fold (0.09 log units) below, within the range that was stated.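

On the core of compound 2, putting the group of 8 heavy atoms that holds selenium and a six-membered aromatic ring in place of methylsulfanyl, on the carbon with a double bond to nitrogen, gives a 1.1-fold lower number from compound 2 to compound 4 (0.03 log units; within the scatter) in this assay, so no order is claimed between these two compounds. Set beside the same change on the core of compound 1, the two steps cannot be told apart on the present data: the same change on two cores in this assay, an at least 1.5-fold lower number (0.20 log units; that floor lies within the scatter) from compound 1 to compound 3 and a 1.1-fold lower number (0.03 log units; within the scatter) from compound 2 to compound 4; the limit leaves it open whether they differ. This shows that on the core of compound 2 the change leaves no step beyond the scatter, but it does not show that the change carries between the two cores with the same size, nor that its size depends on the core, since the step on the core of compound 1 starts from a limit of the assay: the limit of > 100000 nM in this assay, at which 1 of the 4 values shown sits.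

The compounds shown place only methylsulfanyl and this selenium-bearing group on that carbon, so it stays open how an amine, a carboxylic acid or a longer carbon chain in the same place would read in this assay. Going by these compounds, it also stays open how large the step on the core of compound 1 would be if that core's methylsulfanyl compound gave a number instead of a limit.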